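A few compounds are considered here, and "the series" means these few. Any claim that something is new, unique, unknown or untested is made for them only; others in the source may bear on it.

Measured compounds: compound 1 `CSCC[C@H](NC(=O)[C@H](C)NC(=O)[C@H](C)NC(=O)CC[C@H](NS(=O)(=O)c1ccc(Cl)c(C(F)(F)F)c1)C(=O)O)C(N)=O` with 6700 nM, compound 2 `CC(C)C[C@H](NC(=O)[C@H](C)NC(=O)CC[C@H](NS(=O)(=O)c1ccc(Cl)c(C(F)(F)F)c1)C(=O)O)C(=O)N[C@@H](C)C(N)=O` with 1700 nM, compound 3 `CSCC[C@H](NC(=O)[C@H](CC(C)C)NC(=O)[C@H](CO)NC(=O)CC[C@H](NS(=O)(=O)c1ccc(Cl)c(C(F)(F)F)c1)C(=O)O)C(N)=O` with 5700 nM, all in an assay on isolated protein for inhibition of Matrilysin (Homo sapiens), read by fluorescence, with a stated time of 15 min; on this read-out lower numbers stand for stronger inhibition and higher numbers for weaker inhibition.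

Compound 3 sits second highest of the three numbers in this assay. Its value lies within the scatter of compound 1, so no order between these two can be read; compound 2 gives a lower number that lies beyond the scatter from compound 3. Compound 4 `CSCC[C@H](NC(=O)[C@H](CC(C)C)NC(=O)[C@H](CC(C)C)NC(=O)CC[C@H](NS(=O)(=O)c1ccc(Cl)c(C(F)(F)F)c1)C(=O)O)C(N)=O` is not yet measured. It differs from compound 3 by isopropyl in place of hydroxy on a saturated chain carbon, two bonds along the chain from an amide-type nitrogen and a carbonyl carbon. Among the measured compounds shown here, no measured pair shows this change, so the step of a 1.6-fold lower number from compound 3 to compound 4 (0.21 log units; within the scatter) is an expectation only: a small lowering, possibly within the scatter. Compound 4 is expected to give about 3500 nM, between 1200 nM and 10000 nM.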

Compound 4, half-maximal inhibitory concentration: 780 nM
Beside the measured number, compound 4's estimate is 4.5-fold (0.65 log units) above it; the whole stated range lies above it.
By their numbers in this assay, from the lowest: compound 4; then compound 2; then compounds 3 and 1 (each within the scatter of the next).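

In this assay, isopropyl in place of hydroxy on this saturated chain carbon, two bonds along the chain from an amide-type nitrogen and a carbonyl carbon, gives a 7.3-fold lower number from compound 3 to compound 4 (0.86 log units; beyond the scatter) and so lies beyond the scatter. The earlier compounds shown here, none of which differed in one place, could not show that the number responds to the group at this carbon. Still open, on these data alone, is how an amine, a carboxylic acid or a longer chain at this carbon would read. Nothing at hand accounts for the step.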